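Flipping both ring stereocentres of compound 3

This account rests on a few compounds, and the source may have more. Where it says the series, first, only, none or still open, it means among the compounds named here.

Of the compounds shown here, three share one core and have been measured in an assay on Sf9 cells for inhibition of histone deacetylase 11 (Homo sapiens), read by fluorescence, tested at 0.5 uM; a higher number here means more inhibition at the concentration tested (going by the name of the read-out), a lower number less inhibition. Compound 1, `O=C(/C=C/c1cn([C@@H]2C[C@@H](C(=O)O)N(Cc3ccccc3)C2)nn1)NO`, gives 12%. Compound 2, `O=C(/C=C/c1cn([C@H]2C[C@@H](CO)N(Cc3ccccc3)C2)nn1)NO`, gives 35%, and compound 3, `O=C(/C=C/c1cn([C@H]2C[C@H](CO)N(Cc3ccccc3)C2)nn1)NO`, gives 20%. Compound 3 stands second highest of the three numbers: its gap to compound 1 lies within the usual scatter, while compound 2 lies beyond it.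

Compound 4 is `O=C(/C=C/c1cn([C@@H]2C[C@@H](CO)N(Cc3ccccc3)C2)nn1)NO`. Its change from compound 3 is the two compounds have the same atoms and bonds and differ only in configuration as drawn: 2 of 3 stereo elements differ; a stereocentre at a saturated ring carbon is drawn S in compound 3 and R in compound 4; a stereocentre at a saturated ring carbon is drawn R in compound 3 and S in compound 4.

Going by the values given here, only one measured step bears on this kind of change: a number 15 percentage points lower from compound 2 to compound 3 (beyond the scatter), where the two compounds differ in configuration alone (the fact that compounds 2 and 3 differ only in the configuration as drawn). That step shows that turning a single ring stereocentre can move the read-out by a modest amount. Here two stereocentres turn at once, and no measured pair shows that double change, so the direction is open. The expected step of a number 5 percentage points higher from compound 3 to compound 4 (within the scatter) is therefore small and uncertain. Compound 4 is estimated to give 25% in this assay, within a range from 10% to 40%.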

Compound 4, a percentage reported as inhibition, at one concentration (the size of the read-out at that concentration, not a potency): < 10%
Compound 4 was reported as a limit; the forecaster's own chance of this, stated with the estimate: 0%; middle value at least 15 percentage points away from the limit.
By their numbers in this assay, from the lowest: compounds 1 and 3 (each within the scatter of the next); then compound 2. At a limit, below all of these: compound 4.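

In this assay, compound 4 gives < 10%, which is a limit of the assay and not a number. Turning only the ring stereocentre left untouched in the earlier pair gives a number at least 25 percentage points lower from compound 2 to compound 4 (beyond the scatter), so the read-out depends on the configuration at this second centre as well, with no change in atoms or bonds: the fact that compounds 2 and 4 differ only in the configuration as drawn. The other two steps, a number at least 10 percentage points lower from compound 3 to compound 4 (that floor lies within the scatter) and a number at least 2 percentage points lower from compound 1 to compound 4 (that floor lies within the scatter), rest on floors within the scatter, so neither can be read as a real difference.

The compounds shown leave open how the fourth arrangement of these two ring stereocentres would behave. They also leave open whether an aminomethyl group in place of hydroxymethyl, in the configuration of compound 2, would keep or change the read-out.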